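The source may hold more compounds than are shown below. What is called first, only, known or untested is meant among the compounds shown, and "the series" means these compounds.

Working notes on the series.

Of the compounds shown here, two have numbers so far. Compound 1 `Oc1cc(F)ccc1C(c1ccc2ccoc2c1O)N1CCCCC1` is one of them; in an assay for inhibition of protein disulfide-isomerase (Homo sapiens), with a stated time of 1 h (on this read-out higher numbers stand for weaker inhibition and lower numbers for stronger inhibition), compound 1 gives 1070 nM. The other, compound 2 `Cc1ccnc(NC(c2ccc(C(F)(F)F)cc2)c2ccc3cccnc3c2O)c1`, gives 26500 nM in this assay. Compound 1 therefore holds the lower of the two numbers, and compound 2 stands at a higher number, a gap well beyond the scatter. Compounds 1 and 2 differ at several places at once, so the two values say nothing about any single change.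

The next compound, compound 3 `Oc1c(C(c2ccc(F)cc2)N2CCCCC2)ccc2ccoc12`, differs from compound 1 in one place only: hydrogen in place of hydroxy on an aromatic carbon. It removes a hydroxy that sits on an aromatic carbon of a six-membered aromatic ring of carbon only, so that one hydrogen-bond donor and one hydrogen-bond acceptor are gone from the molecule. Going by the values given here, no measured pair isolates this change, so there is no step to lean on.

Expectation: the loss of the hydroxy is taken to weaken inhibition modestly, a step in the direction of a higher number that may or may not clear the scatter, written as a 2.8-fold higher number from compound 1 to compound 3 (0.45 log units; beyond the scatter). For compound 3 in this assay the estimated value is 3000 nM, with a range from 1000 nM to 10000 nM.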

Compound 3, half-maximal inhibitory concentration: 560 nM
Compound 3: middle estimate off by 5.4-fold (0.73 log units), on the high side; the measured number lies below the stated range.
By their numbers in this assay, from the lowest: compounds 3 and 1 (each within the scatter of the next); then compound 2.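

Going by these compounds alone, the exchange of 4-fluoro-2-hydroxyphenyl for 4-fluorophenyl gives the first step that isolates a single place: in this assay, the step reads (a 1.9-fold lower number from compound 1 to compound 3 (0.28 log units; within the scatter)), so this pair cannot be told apart on this read-out. For this pair, the hydroxy on an aromatic carbon, ortho to a large group and meta to a fluoro group, is thus not needed to keep inhibition at the level of compound 1, although a single step cannot show whether that holds elsewhere in the series. No measurement bears on why the hydroxy can be exchanged for hydrogen without a change beyond the scatter, and no explanation can be offered for this result.

Going by these compounds, it remains open what a different group at this place would give, such as a methoxy, an amine or a carboxylic acid, each of which would test more than the plain absence of the hydroxy. Also open, on these data alone, is whether the remaining hydroxy on the core of compound 3 contributes to inhibition, and whether the same exchange gives a similar step on a different core such as that of compound 2.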